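Aryl swap on the triazole series, compound 2 to compound 3

The source may report more compounds than this note shows. Statements on the series, on what has been measured and on what is new or still open speak of the compounds shown alone.

Measured in a functional assay on SGC-7901 cells (Homo sapiens) for inhibition, read by MTT assay, with a stated time of 24 h; a higher number here means a weaker inhibitor, a lower number a stronger inhibitor:
- compound 1 `CC1(C)[C@H]2CC[C@]1(C)N(Cc1cn(-c3ccc(Cl)cc3)nn1)C(=O)C2`: 410 nM
- compound 2 `COc1ccc(-n2cc(CN3C(=O)C[C@@H]4CC[C@@]3(C)C4(C)C)nn2)cc1`: 480 nM

In this assay, among the measured compounds shown here, compound 2 gives 480 nM and stands within the scatter of compound 1, the only other measured compound. Compound 3 `Cc1cccc(-n2cc(CN3C(=O)C[C@@H]4CC[C@@]3(C)C4(C)C)nn2)c1` has not yet been measured. It carries 3-methylphenyl in place of 4-methoxyphenyl on an aromatic nitrogen of a five-membered aromatic ring with 3 nitrogen, and the counted difference is 3-methylphenyl in place of 4-methoxyphenyl on an aromatic nitrogen.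

For the measured compounds named here, one measured step bears on this change, since it also alters a group on this aromatic ring. That step is a 1.2-fold higher number from compound 1 to compound 2 (0.07 log units; within the scatter), methoxy in place of chloro on an aromatic carbon, and it stays within the scatter. Going by the values given here, no measured compound carries 3-methylphenyl, so this single step is thin evidence and the range is kept wide. No step beyond the scatter is expected in this assay, and no direction can be called. The expected step is a 1.1-fold lower number from compound 2 to compound 3 (0.03 log units; within the scatter), which is within the scatter. For compound 3 the estimated value is 450 nM, with an expected range of 200 nM to 1000 nM.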

Compound 3, half-maximal inhibitory concentration: 410 nM
For compound 3 the middle estimate is 1.1-fold (0.04 log units) above the measured one; low and high end bracket the measured number.
By their numbers in this assay, from the lowest: compounds 1, 3 and 2 (each within the scatter of the next).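

In this assay, 3-methylphenyl in place of 4-methoxyphenyl on the aromatic nitrogen gives a 1.2-fold lower number from compound 2 to compound 3 (0.07 log units; within the scatter), so this position now tolerates a substituent other than the two already seen, and a group with 0 hydrogen-bond acceptors reads the same within the scatter as one with 1. The comparison with the chloro compound gives no change at the digits printed from compound 1 to compound 3 (within the scatter), so all three aryl groups on this nitrogen stand within the scatter of one another, and none of the listed compounds goes against that. The data offer no measurement that would explain this flatness.

The swap changes both the substituent and its place on the phenyl ring, and 4-methylphenyl would be needed to separate those two changes. Going by these compounds, whether an amine or a carboxylic acid on the phenyl ring, or a longer chain in place of the methyl group, would give a step beyond the scatter in this assay remains open.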